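Fluorocyclopropyl amide stereoisomer at the shared core

A few compounds are considered here, and "the series" means these few. Any claim that something is new, unique, unknown or untested is made for them only; others in the source may bear on it.

compound 1 `CCCC(=O)N1CC2CC(C1)N2`: 300 nM
compound 2 `O=C([C@@H]1C[C@@H]1F)N1CC2CC(C1)N2`: 88 nM

In an assay on CHO cells for agonist activity at Neuronal acetylcholine receptor; alpha3/alpha6/beta2/beta3 (Homo sapiens), read by FLIPR and calcium flux (on this read-out lower numbers stand for an effect already at smaller amounts and higher numbers for an effect only at larger amounts of compound), compound 2 holds the lowest of the two numbers; its nearest neighbour is compound 1, the acyl exchange giving a 3.4-fold lower number from compound 1 to compound 2 (0.53 log units; beyond the scatter). Compound 3 `O=C([C@H]1C[C@@H]1F)N1CC2CC(C1)N2` differs from compound 2 in one point only: the two compounds have the same atoms and bonds; at least one stereo element is drawn with a configuration in one of them and without one in the other: 1 of 4 stereo elements differ; a stereocentre at a saturated ring carbon is drawn S in compound 2 and R in compound 3. The single measured step swaps whole groups and says nothing about configuration; no measured pair here separates stereoisomers, so the expected size rests on no shown step. For compound 3 the estimate is 150 nM, from 30 nM to 900 nM. The step this implies, a 1.7-fold higher number from compound 2 to compound 3 (0.23 log units; within the scatter), is expected to sit within the scatter, with the wide range covering either direction.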

Compound 3, half-maximal effective concentration: 620 nM
Beside the measured number, compound 3's estimate is 4.1-fold (0.62 log units) below it; the range from low to high includes it.
By their numbers in this assay, from the lowest: compound 2; then compound 1; then compound 3.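

Configuration at this saturated ring carbon matters in this assay: with atoms and bonds unchanged, the change from S to R gives a 7.0-fold higher number from compound 2 to compound 3 (0.85 log units; beyond the scatter). The lower number for 2-fluorocyclopropyl in place of propyl therefore holds for compound 2 only, as the same exchange with the R drawing gives a 2.1-fold higher number from compound 1 to compound 3 (0.32 log units; beyond the scatter). Reading the two compounds as a clean stereoisomer pair carries one reservation: the fact that one of compounds 2 and 3 is drawn with a defined configuration and the other without, at the place where they differ.

Open, from the compounds shown here alone, is whether the fluorine is needed at all, as a plain cyclopropyl amide would show. Going by these compounds, the remaining stereoisomers of the 2-fluorocyclopropyl amide also stay open.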